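Trading a furan for a methylphenyl on a cyanoacrylamide chain

The compounds below may be only part of what the source reports. "The series", "measured", "known", "first", "only" and "open" are said of these compounds alone.

Compound 1, `N#C/C(=C\c1c(F)c(F)c(F)c(F)c1F)C(=O)c1ccc[nH]1`, 23000 nM
Compound 2, `N#C/C(=C\c1ccc[nH]1)C(=O)NCc1ccc(Cl)c(Cl)c1`, 6000 nM
Compound 3, `COc1ccc(CNC(=O)/C(C#N)=C/c2ccco2)cc1`, 27000 nM

Of the compounds shown here, three have been tested in a functional assay on MCF7 cells (Homo sapiens) for inhibition, read by MTT assay, with a stated time of 72 h; on this read-out lower numbers stand for stronger inhibition of growth and higher numbers for weaker inhibition of growth. Compound 3, `COc1ccc(CNC(=O)/C(C#N)=C/c2ccco2)cc1`, gives 27000 nM, the highest of the three numbers. Its nearest neighbour is compound 1, `N#C/C(=C\c1c(F)c(F)c(F)c(F)c1F)C(=O)c1ccc[nH]1`, with 23000 nM, a gap that falls within the usual scatter, so the two cannot be told apart. Compound 2, `N#C/C(=C\c1ccc[nH]1)C(=O)NCc1ccc(Cl)c(Cl)c1`, with 6000 nM, lies furthest away, beyond the scatter, so it inhibits growth more strongly than compound 3.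

The next compound to consider is compound 4, `COc1ccc(CNC(=O)/C(C#N)=C/c2ccc(C)cc2)cc1`. It differs from compound 3 in a single place: 4-methylphenyl in place of furan-2-yl on a double-bonded chain carbon bound to a double-bonded chain carbon. Among the measured compounds shown here, no measured pair in this set shows what such an exchange does, so there is nothing to copy from. The shared amide part stays unchanged. For the measured compounds named here, with no guide from measured steps, the step from compound 3 to compound 4 in this assay is expected to be small, a 1.2-fold lower number from compound 3 to compound 4 (0.09 log units; within the scatter), in no clear direction beyond the scatter. Compound 4 is therefore estimated to give 22000 nM, with a range from 7000 nM to 70000 nM.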

Compound 4, concentration for 50% growth inhibition: 36000 nM
For compound 4 the middle estimate is 1.6-fold (0.21 log units) below the measured one; the measured number falls inside the stated range.
By their numbers in this assay, from the lowest: compound 2; then compounds 1, 3 and 4 (each within the scatter of the next).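

In this assay, putting 4-methylphenyl in place of furan-2-yl on a double-bonded chain carbon bound to a double-bonded chain carbon gives a 1.3-fold higher number from compound 3 to compound 4 (0.12 log units; within the scatter) and this step lies within the scatter. Among the compounds shown here, this is the first comparison in the set that changes one place only, and it shows that, with the amide part held fixed, a five-membered aromatic ring with one oxygen and a six-membered aromatic ring of carbon only cannot be told apart here. No measurement at hand bears on why the two read alike. Going by these compounds, whether an amine or a carboxylic acid on the ring, or a longer chain in its place, would shift the number beyond the scatter stays open. So does whether this exchange would read the same with a different amide part.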